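Sulfur to Oxygen in a Fused Ring

A few compounds are considered here, and "the series" means these few. Any claim that something is new, unique, unknown or untested is made for them only; others in the source may bear on it.

Compound 1 `c1ccc(-c2ccc(Cn3cncc3CNc3ccc(-c4nc5ccccc5s4)c(-c4ccccc4)c3)cc2)cc1` and compound 2 `Cc1cccc(-c2cc(NCc3cncn3Cc3ccc(-c4ccccc4)cc3)ccc2-c2nc3ccccc3s2)c1C` share one core and were both tested in a toxicity assay on NIH3T3 cells (Mus musculus) for cytotoxicity, read by resazurin assay; a higher number here means that more compound is needed for the effect, a lower number that less compound is needed. Compound 1 reaches only the limit of the test there, > 1000 nM. Compound 2 likewise reaches only a limit, > 1000 nM. Among the compounds with values here, the step that the two limits leave unreadable from compound 1 to compound 2 therefore cannot be sized, and the sole evidence is the limit of > 1000 nM in this assay, at which 2 of the 2 values shown sit. Compound 3 `c1ccc(-c2ccc(Cn3cncc3CNc3ccc(-c4noc5ccccc45)c(-c4ccccc4)c3)cc2)cc1` differs from compound 1 by a group of 9 heavy atoms (7 carbon, 1 nitrogen, 1 oxygen; one five-membered aromatic ring with 2 hetero atoms, one six-membered aromatic ring of carbon only) in place of a group of 9 heavy atoms (7 carbon, 1 nitrogen, 1 sulfur; one five-membered aromatic ring with 2 hetero atoms, one six-membered aromatic ring of carbon only), on an aromatic carbon. Within the data shown here, no measured step resembles this change, so no shift beyond the scatter is expected in this assay. Compound 3 is expected to give 3000 nM, between 1000 nM and 10000 nM. The estimated step is a step that the limit leaves unreadable from compound 1 to compound 3.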

Compound 3, half-maximal effective concentration: > 10000 nM
Compound 3: only a limit was reported; the forecaster's own chance of this, stated with the estimate: 80%; middle value at least 3.3-fold (0.52 log units) from the limit.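

Within the data shown here, compound 1 and compound 3 each reach only a limit of the test in this assay, so no step between them can be read. The compounds shown leave open what concentration any of them needs for the effect, and whether exchanging sulfur for oxygen changes it at all.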